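A few compounds are considered here, and "the series" means these few. Any claim that something is new, unique, unknown or untested is made for them only; others in the source may bear on it.

Compound 3 `O=C(O)CCC/C=C\C[C@H]1[C@@H]2CCC(C2)[C@@H]1NS(=O)(=O)c1ccc(O)cc1` gives 500 nM in a functional assay (plasma) for inhibition, with Oryctolagus cuniculus as the target; a higher number here means a weaker inhibitor, a lower number a stronger inhibitor. Compound 1 `O=C(O)CCC/C=C\C[C@H]1[C@@H]2CCC(C2)[C@@H]1NS(=O)(=O)c1ccc(F)cc1` gives 600 nM in this assay, and the two are inseparable, as a 1.2-fold lower number from compound 1 to compound 3 (0.08 log units; within the scatter) shows. Compound 2 `O=C(O)CCC/C=C\C[C@H]1[C@@H]2CCC(C2)[C@@H]1NS(=O)(=O)CCCc1ccccc1` gives 14000 nM, far from both: a 23-fold higher number from compound 1 to compound 2 (1.37 log units; beyond the scatter) and a 28-fold lower number from compound 2 to compound 3 (1.45 log units; beyond the scatter) are the only large movements among the three, and both come from exchanging the aryl group on the sulfonyl sulfur for 3-phenylpropyl, not from a change on the ring itself.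

Compound 4 `O=C(O)CCC/C=C\C[C@H]1[C@@H]2CCC(C2)[C@@H]1NS(=O)(=O)c1ccc(C(=O)O)cc1` differs from compound 3 at one point: carboxy in place of hydroxy on an aromatic carbon. Among the compounds with values here, the only step that touches that aromatic carbon is a 1.2-fold lower number from compound 1 to compound 3 (0.08 log units; within the scatter), which stayed within the scatter. Nothing shown speaks to a carboxy at that place, so the expectation for compound 4 in this assay rests on that single quiet step, and the estimated change from compound 3 is a modest one, a 1.6-fold higher number from compound 3 to compound 4 (0.20 log units; within the scatter), with a wide allowance for surprise. Compound 4 is therefore expected to give about 800 nM, estimated to lie between 250 nM and 3000 nM.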

Compound 4, half-maximal inhibitory concentration: 800000 nM
Compound 4: middle estimate off by 1000-fold (3.00 log units), on the low side, and the stated range ends below it.
By their numbers in this assay, from the lowest: compounds 3 and 1 (each within the scatter of the next); then compound 2; then compound 4.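

The aromatic carbon para to a large group had seemed indifferent when hydroxy and fluoro were exchanged, but in this assay it tolerates carboxy poorly, with a 1600-fold higher number from compound 3 to compound 4 (3.20 log units; beyond the scatter) and, measured against fluoro, a 1300-fold higher number from compound 1 to compound 4 (3.12 log units; beyond the scatter). The 4-carboxyphenyl group also falls behind 3-phenylpropyl on the sulfonyl sulfur, with a 57-fold higher number from compound 2 to compound 4 (1.76 log units; beyond the scatter), which reverses the earlier finding that the aryl groups on that sulfur gave the lower numbers. No measurement offered here accounts for this loss.

From the compounds shown here alone, it remains open whether a methyl ester, a primary amide or a tetrazole at the same aromatic carbon would give a similarly high number or stay close to hydroxy and fluoro. Also open, going by these compounds, is how a carboxylic acid at the end of a longer chain on the sulfonyl sulfur would compare.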